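The compounds below may be only part of what the source reports. "The series", "measured", "known", "first", "only" and "open" are said of these compounds alone.

Measured so far:
- compound 1 `O=C1O[C@@H](CO)CN1c1ccc(-n2cc(-c3ccccn3)cn2)c(F)c1`: in an ADME assay on HEK293-A cells (Homo sapiens) for cytotoxicity, read by MTT assay, with a stated time of 48 h (a higher number here means a weaker inhibitor, a lower number a stronger inhibitor), compound 1 gives > 400 ug/mL, which is a limit of the assay and not a number.
- compound 2 `O=C1O[C@@H](CN2CCCCC2)CN1c1ccc(-n2cc(-c3ccccn3)cn2)c(F)c1`: in this assay compound 2 gives > 400 ug/mL, again a limit of the assay.
- compound 3 `O=C1CCC(=O)N1C[C@H]1CN(c2ccc(-n3cc(-c4ccccn4)cn3)c(F)c2)C(=O)O1`: in this assay compound 3 gives > 400 ug/mL, also a limit of the assay.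

Compound 2 therefore stands at the ceiling of what was measured, and so do the other two values shown: all three sit at the limit of > 400 ug/mL in this assay, at which 3 of the 3 values shown sit. No ordering among the three compounds can be read from this.

Compound 4 `CN(C)S(=O)(=O)NC[C@H]1CN(c2ccc(-n3cc(-c4ccccn4)cn3)c(F)c2)C(=O)O1` differs from compound 2 in one place: (dimethylsulfamoyl)amino in place of piperidin-1-yl on a saturated chain carbon bound to a saturated ring carbon.

The measured steps that bear on this change are the ones at the same place, a step that the two limits leave unreadable from compound 1 to compound 2, a step that the two limits leave unreadable from compound 1 to compound 3 and a step that the two limits leave unreadable from compound 2 to compound 3. Each of them joins two limits, so none of them has a readable size, and no direction beyond the scatter can be drawn from them for the step to compound 4.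

Compound 4 is expected to come out at 500 ug/mL, between 200 ug/mL and 1200 ug/mL, most likely again reported only as a limit. The expected step from compound 2 is estimated as a step that the limit leaves unreadable from compound 2 to compound 4.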

Compound 4, half-maximal inhibitory concentration: 249 ug/mL
For compound 4 the middle estimate is 2.0-fold (0.30 log units) above the measured one; measured number inside the range.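

In this assay compound 4 is the only compound shown with a number rather than a limit, so this place, on a saturated chain carbon bound to a saturated ring carbon, now gives readable steps: an at least 1.6-fold lower number from compound 2 to compound 4 (0.20 log units; that floor lies within the scatter), an at least 1.6-fold lower number from compound 3 to compound 4 (0.20 log units; that floor lies within the scatter) and an at least 1.6-fold lower number from compound 1 to compound 4 (0.20 log units; that floor lies within the scatter). Each floor lies within the scatter, so (dimethylsulfamoyl)amino cannot yet be said to lower the number relative to piperidin-1-yl, 2,5-dioxopyrrolidin-1-yl or hydroxy, though the true gaps may be larger. The steps among compounds 1, 2 and 3 still cannot be read, and those compounds share one ceiling: the limit of > 400 ug/mL in this assay, at which 3 of the 4 values shown sit.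

From the compounds shown here alone, the true size of the gaps to compound 4 stays open. Also open, going by these compounds, is whether methanesulfonylamino, acetamido or a carboxylic acid at this place would give a readable number.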